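Carbamoyl in Place of Carboxymethyl: From Compound 3 to Compound 4

This account rests on a few compounds, and the source may have more. Where it says the series, first, only, none or still open, it means among the compounds named here.

Of the compounds shown here, three built on a shared core have been measured in a functional assay on the whole organism (Tail, strain ICR) with Mus musculus as the target, in the tail flick test, with a stated time of 90 min, at a dose of 25 umol/kg by the oral route; a higher number here means a stronger effect of the compound at the dose given, a lower number a weaker effect. Compound 1 `N=C(N)NCCC[C@H](NC(=O)CN(c1ncnc2c1ncn2C1CCCCO1)C1CC1)C(=O)OCc1ccccc1` gives 61.6%. Compound 2 `O=C(OCc1ccccc1)[C@@H]1CCCN1C(=O)CN(c1nc(Cl)nc2[nH]cnc12)C1CC1` gives 43.3%, and compound 3 `O=C(O)CC[C@H](NC(=O)CN(c1nc(Cl)nc2[nH]cnc12)C1CC1)C(=O)O` gives 44.7%. Among these three numbers compound 3 stands second highest: its nearest neighbour is compound 2, whose value lies within the usual scatter of it, and the furthest is compound 1, whose value lies beyond the scatter above it.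

Compound 4 `NC(=O)C[C@H](NC(=O)CN(c1nc(Cl)nc2[nH]cnc12)C1CC1)C(=O)O` has not yet been measured in this assay. It differs from compound 3 in one place: carbamoyl in place of carboxymethyl on a saturated chain carbon, two bonds along the chain from an amide-type nitrogen and a carbonyl carbon. Within the data shown here, no pair of measured compounds shows a step of this kind, so the change has no precedent among the numbers known here, and a shift of any size beyond the scatter cannot be grounded in them.

Compound 4 is therefore expected to give 45% in this assay, within a range from 30% to 60%. The step this estimate means, a number 0.3 percentage points higher from compound 3 to compound 4 (within the scatter), is expected to be none beyond the scatter.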

Compound 4, a percentage reported as activity, at one dose (the size of the read-out at that dose, not a potency): 20.1%
Compound 4: middle estimate off by 24.9 percentage points, on the high side; measured number below the stated range.
By their numbers in this assay, from the lowest: compound 4; then compounds 2 and 3 (each within the scatter of the next); then compound 1.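

The step of a number 24.6 percentage points lower from compound 3 to compound 4 (beyond the scatter) in this assay is the only one shown between compounds that differ in one place. It shows that the read-out at the given dose responds to what stands on this saturated chain carbon, something the three earlier compounds, which differ in several places at once, could not reveal. Nothing measured here accounts for the size or direction of this step.

The compounds shown do not separate the loss of the carboxylic acid from the shortening of the chain, since both come with the same change; a longer chain ending in carbamoyl, such as 2-carbamoylethyl, or an amine at this place would bear on that. From the compounds shown here alone, whether the step would carry over to the other compounds, with their different amino acid parts, also stays open.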